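Sulfonyl aryl variation in a sulfonamide series

The compounds below may be only part of what the source reports. "The series", "measured", "known", "first", "only" and "open" are said of these compounds alone.

Measured so far:
compound 1 `CC(C)Cc1cc(CNS(=O)(=O)c2cccc(Cl)c2)nn1-c1ccccc1`: 40.8%
compound 2 `CC(C)Cc1cc(CNS(=O)(=O)c2cccc3ccccc23)nn1-c1ccccc1`: 77.7%
compound 3 `O=C1c2[nH]nc(NS(=O)(=O)c3ccc4ccccc4c3)c2CCN1CC1CCNCC1`: 94.1%

In an assay on isolated protein for binding affinity to 5-hydroxytryptamine receptor 6 (Homo sapiens), tested at 10 uM (a lower number here means less inhibition, a higher number more inhibition at the concentration tested (going by the name of the read-out)), compound 2 stands second highest of the three numbers, with compound 3 above it and compound 1 below it, both gaps beyond the scatter. Among the compounds with values here, the only single-point step measured is a number 36.9 percentage points higher from compound 1 to compound 2 (beyond the scatter), a large gain. Compound 4 `CC(C)Cc1cc(CNS(=O)(=O)c2ccc(C(C)(C)C)cc2)nn1-c1ccccc1` differs from compound 2 in one place: 4-(tert-butyl)phenyl in place of naphthalen-1-yl on a sulfonyl sulfur. Within the data shown here, no measured pair covers this exact exchange. The step from compound 1 to compound 2 shows that the group on the sulfonyl sulfur moves the read-out strongly in this series, and compound 4 goes back from two six-membered aromatic rings to one, as in compound 1, though with a different group on that ring. The expectation is therefore a drop from compound 2, short of the full step back to compound 1, with wide uncertainty. The estimated step is a number 22.7 percentage points lower from compound 2 to compound 4 (beyond the scatter). Compound 4 is expected to give 55%, within 30% to 80%.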

Compound 4, a percentage reported as inhibition, at one concentration (the size of the read-out at that concentration, not a potency): 51.1%
For compound 4 the middle estimate is 3.9 percentage points above the measured one; the range from low to high includes it.
By their numbers in this assay, from the lowest: compound 1; then compound 4; then compound 2; then compound 3.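

In this assay, the exchange on the sulfonyl sulfur gives a number 26.6 percentage points lower from compound 2 to compound 4 (beyond the scatter), so two groups with the same count of 10 heavy atoms, naphthalen-1-yl and 4-(tert-butyl)phenyl, do not read alike, and heavy-atom count alone does not set the number at this position. The two single-ring groups also separate from each other, with a number 10.3 percentage points higher from compound 1 to compound 4 (beyond the scatter), yet both stay under the naphthalen-1-yl of compound 2, so among these three compounds the two-ring group reads highest. No measured information is available to explain these differences.

Still open, from the compounds shown here alone, is how a phenyl carrying an amine or a carboxylic acid on the sulfonyl sulfur would read on this core. Within the data shown here, compound 3 differs from the others in more than one place, so it gives no step for this position.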